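The source may hold more compounds than are shown below. What is called first, only, known or untested is meant among the compounds shown, and "the series" means these compounds.

Measured in an ADME assay on microsomes from liver (Homo sapiens) for metabolic stability; on this read-out lower numbers stand for a shorter-lived compound and higher numbers for a longer-lived compound:
- compound 1 `CC(C)C(/C=C1\NC(=O)NC1=O)c1ccc(-c2ccc3cccc(F)c3c2)[nH]c1=O`: > 3 h (a limit of the assay, not a number)
- compound 2 `CC(C)C(CC1C(=O)NC(=O)N1C)c1ccc(-c2ccc3cccc(F)c3c2)[nH]c1=O`: 0.153 h
- compound 3 `CC(C)C(c1ccc(-c2ccc3cccc(F)c3c2)[nH]c1=O)C1NC(=O)NC1=O`: 0.578 h

Of the two actual numbers, compound 3 holds the higher. The other one, in compound 2, is its nearest neighbour. Compound 1 stands at the limit of > 3 h in this assay, at which 1 of the 3 values shown sits.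

Compound 4 `CC(C)C(c1ccc(-c2ccc3cccc(F)c3c2)[nH]c1=O)C1SC(=O)NC1=O` differs from compound 3 in one place: 2,4-dioxo-1,3-thiazolidin-5-yl in place of 2,5-dioxoimidazolidin-4-yl on a saturated chain carbon bound to an aromatic carbon and a saturated chain carbon.

All three measured steps change the group at this same place, so the read-out clearly responds there. They are an at least 19-fold lower number from compound 1 to compound 2 (1.29 log units; beyond the scatter), an at least 5.1-fold lower number from compound 1 to compound 3 (0.71 log units; beyond the scatter) and a 3.8-fold higher number from compound 2 to compound 3 (0.58 log units; beyond the scatter). The first two start from a limit, so their sizes are bounds only. The last is modest. None of the three exchanges one ring hetero atom for another while keeping the ring, so none gives a direction for this change.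

With no direction to draw on, no step beyond the scatter is expected, although a modest move either way remains possible. The expected step is a 1.2-fold lower number from compound 3 to compound 4 (0.06 log units; within the scatter). For compound 4 the estimate is 0.5 h, with an expected range of 0.17 h to 1.5 h.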

Compound 4, half-life: 1.87 h
For compound 4 the middle estimate is 3.7-fold (0.57 log units) below the measured one; the measured number lies above the stated range.
By their numbers in this assay, from the lowest: compound 2; then compound 3; then compound 4. At a limit, above all of these: compound 1.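

Keeping the five-membered non-aromatic ring and exchanging 2,5-dioxoimidazolidin-4-yl for 2,4-dioxo-1,3-thiazolidin-5-yl moves the read-out in this assay beyond the scatter, which gives this place its first direction for a change of ring hetero atoms (a 3.2-fold higher number from compound 3 to compound 4 (0.51 log units; beyond the scatter)). The thiazolidine group also stands well clear of the longer (3-methyl-2,5-dioxoimidazolidin-4-yl)methyl group (a 12-fold higher number from compound 2 to compound 4 (1.09 log units; beyond the scatter)), so among the three compounds with a number, compound 4 holds the highest. The remaining step starts from a limit, so its size is a bound only (an at least 1.6-fold lower number from compound 1 to compound 4 (0.20 log units; that floor lies within the scatter)). Compound 1 carries a limit of the assay, not a number: the limit of > 3 h in this assay, at which 1 of the 4 values shown sits.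

The compounds shown do not tell whether the rise follows the sulfur itself or the shift in hydrogen-bond donors and acceptors that comes with it, nor whether it would carry over to the longer chain of compound 2 or the unsaturated link of compound 1. A 2,4-dioxo-1,3-oxazolidin-5-yl group or a carboxylic acid at this place would show how far the half-life depends on the ring hetero atom and on the ring as a whole.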